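This account rests on a few compounds, and the source may have more. Where it says the series, first, only, none or still open, it means among the compounds named here.

Measured in a functional assay on the whole organism for positive allosteric modulation, with Mus musculus as the target; a higher number here means that more compound is needed for the effect, a lower number that less compound is needed:
Compound 1 `CCC(=O)N(c1ccc(Br)cc1)C1CCCC1N(C)C`: 2 mg/kg
Compound 2 `CCC(=O)N(c1ccc([N+](=O)[O-])cc1)C1CCCC1N(C)C`: 20 mg/kg

Compound 2 has the higher of these two numbers, so more of it is needed for the effect. Compound 3 `CCC(=O)N(c1ccc(C(=O)OC)cc1)C1CCCC1N(C)C` carries methoxycarbonyl in place of nitro on an aromatic carbon. Going by the values given here, one measured step bears on this change: a 10-fold higher number from compound 1 to compound 2 (1.00 log units; beyond the scatter), with nitro replacing bromo. It shows that the group at this place can shift the number, but no measurement compares nitro with methoxycarbonyl directly. In this assay, only a small move within the scatter is therefore expected. The expected step is a 1.3-fold lower number from compound 2 to compound 3 (0.12 log units; within the scatter). For compound 3 the estimated value is 15 mg/kg, with an expected range from 4 mg/kg to 50 mg/kg.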

Compound 3, dose for half-maximal effect: > 50 mg/kg
Compound 3 was reported as a limit; the forecaster's own chance of this, stated with the estimate: 5%; at least 3.3-fold (0.52 log units) between middle value and limit.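

In this assay, methoxycarbonyl and nitro match in hydrogen-bond acceptors and net charge, yet exchanging them at this place on the aromatic ring is not a silent change: the result is an at least 2.5-fold higher number from compound 2 to compound 3 (0.39 log units; beyond the scatter). Measured against bromo, the exchange gives an at least 25-fold higher number from compound 1 to compound 3 (1.39 log units; beyond the scatter), so among these three groups bromo needs the least compound. The reading for compound 3 is a limit, not a number: the limit of > 50 mg/kg in this assay, at which 1 of the 3 values shown sits.

From the compounds shown here alone, the true value of compound 3 therefore stays unknown. Going by these compounds, whether chloro, methyl or an amine at this place would match compound 1 also remains open.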